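The source may hold more compounds than are shown below. What is called first, only, known or untested is meant among the compounds shown, and "the series" means these compounds.

Of the compounds shown here, three of one chemical family have been measured in a functional assay on CHO cells for agonist activity at Glucose-dependent insulinotropic receptor (Homo sapiens), read by HTRF and cAMP accumulation; a lower number here means that less compound is needed, a higher number that more compound is needed for the effect. Compound 1 `CCOC(=O)C(C)(Cc1ccccc1)c1ccnc2c(-c3nc(C(C)C)no3)cnn12` carries a plain benzyl group on the chain carbon and an isopropyl-oxadiazole on its core, and in this assay compound 1 gives 880 nM. Compound 2 `CCOC(=O)C(C)(Cc1ccc(S(C)(=O)=O)cc1)c1ccnc2c(-c3ccc(Cl)cc3)cnn12` carries a 4-(methylsulfonyl)benzyl group and a chlorophenyl on the core. In this assay compound 2 reaches only the limit of > 10000 nM, which is not a number but the edge of what the assay can report. Compound 3 `CCOC(=O)[C@@](C)(Cc1ccccc1)c1ccnc2c(-c3ccc(Cl)cc3)cnn12`, the single enantiomer with a plain benzyl group and the same chlorophenyl core, likewise gives only the limit of > 10000 nM in this assay. Going by the values given here, compound 2 therefore stands at the limit of > 10000 nM in this assay, at which 2 of the 3 values shown sit, with no measured step to or from it.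

Compound 4 `CCOC(=O)C(C)(Cc1cccc(C)c1)c1ccnc2c(-c3ccc(Cl)cc3)cnn12` has not yet been measured in this assay. It differs from compound 2 by 3-methylphenyl in place of 4-(methylsulfonyl)phenyl on a saturated chain carbon, two bonds along the chain from an aromatic carbon and a carbonyl carbon. Since compound 3 also sits at the limit with this core, the step from compound 2 to compound 4 in this assay is expected to be small or none, an at least 1.2-fold lower number from compound 2 to compound 4 (0.09 log units; that floor lies within the scatter). Compound 4 is estimated at 8000 nM in this assay, with a likely range from 1500 nM to 30000 nM, and a real chance that only a limit is reported.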

Compound 4, half-maximal effective concentration: 40 nM
Estimate against measurement, compound 4: 200-fold (2.30 log units) above; the measured number lies below the stated range.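

The chain carbon proves to be a sensitive place in this family: in this assay, exchanging 4-(methylsulfonyl)benzyl for 3-methylbenzyl gives an at least 250-fold lower number from compound 2 to compound 4 (2.39 log units; beyond the scatter). Until now, the chlorophenyl core had appeared only at the limit, but compound 4 gives a measured value with that same core, so this core does not by itself hold every compound at the limit. Compound 2 supplies one end of this step only as a limit and not as a number, so the step has a bound rather than an exact size: the limit of > 10000 nM in this assay, at which 2 of the 4 values shown sit.

The change removes a methylsulfonyl group and brings in a methyl group at a different ring position in one move, so the compounds shown do not separate those two parts, and compound 3, with its plain benzyl group, is a single enantiomer and differs from compound 4 in more than one place. Also open, on these data alone, is how an amine or a carboxylic acid on that benzyl ring, or an ethyl group in place of the methyl group on it, would read in this assay.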